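The source may hold more compounds than are shown below. What is called first, only, known or untested is meant among the compounds shown, and "the series" means these compounds.

Measured so far in a toxicity assay on HeLa cells (Homo sapiens) for cytotoxicity, read by MTT assay, with a stated time of 24 h; on this read-out lower numbers stand for stronger inhibition and higher numbers for weaker inhibition:
- compound 1 `CCOC(=O)N1CCN(C(=S)SCC(O)Cn2c([N+](=O)[O-])cnc2C)CC1`: 1610000 nM
- compound 2 `Cc1ncc([N+](=O)[O-])n1CC(O)CSC(=S)N1CCN(c2cccc(Cl)c2Cl)CC1`: 1000000 nM
- compound 3 `CCOC(=O)N1CCN(CC(O)Cn2c([N+](=O)[O-])cnc2C)CC1`: 3670000 nM

Compound 3 gives the highest number of the three in this assay, with compound 1 nearest and compound 2 furthest; both gaps are beyond the scatter.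

Compound 4 `Cc1ncc([N+](=O)[O-])n1CC(O)CN1CCN(c2ccco2)CC1` is not yet measured. It differs from compound 3 by furan-2-yl in place of ethoxycarbonyl on an amine nitrogen in a ring.

For the measured compounds named here, the one comparable step is on the same ring nitrogen, an aryl group for ethoxycarbonyl, though on a different linker: a 1.6-fold lower number from compound 1 to compound 2 (0.21 log units; within the scatter). On that basis no step beyond the scatter is expected, so a 1.3-fold lower number from compound 3 to compound 4 (0.12 log units; within the scatter) is the estimated change, with the number for compound 4 expected near 2800000 nM and between 1300000 nM and 6000000 nM.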

Compound 4, half-maximal inhibitory concentration: 3520000 nM
The estimate for compound 4 lay 1.3-fold (0.10 log units) below the measured number; measured number inside the range.
By their numbers in this assay, from the lowest: compounds 2 and 1 (each within the scatter of the next); then compounds 4 and 3 (each within the scatter of the next).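

In this assay, furan-2-yl in place of ethoxycarbonyl on the amine nitrogen in the ring gives a 1.0-fold lower number from compound 3 to compound 4 (0.02 log units; within the scatter), so a five-membered aromatic ring and the ester do not separate at this position on this linker. With the earlier dichlorophenyl step, this makes two replacements at this nitrogen, on two different linkers, that stay within the scatter, and no listed compound goes against that. No available data explain why this change leaves the number in place.

On these data alone, it remains open whether a carboxylic acid or a primary amine on a longer chain at this nitrogen would move the number beyond the scatter.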